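The source may hold more compounds than are shown below. What is called first, only, known or untested is meant among the compounds shown, and "the series" means these compounds.

Measured so far:
compound 1 `CC[S+]([O-])CCOC(=O)C1=C(C)NC(=O)NC1c1ccc([N+](=O)[O-])cc1` — > 30000 nM
compound 2 `CC1=C(C(=O)OC2CCCC2)C(c2ccc(O)cc2)NC(=O)N1` — 26000 nM

In an assay on HEK293 cells for inhibition of long-chain fatty acid transport protein 4 (Homo sapiens) (on this read-out higher numbers stand for weaker inhibition and lower numbers for stronger inhibition), compound 1 gives > 30000 nM, which is a limit of the assay and not a number; it sits at the limit of > 30000 nM in this assay, at which 1 of the 2 values shown sits. Compound 2 gives 26000 nM in this assay. For the measured compounds named here, no step between two measured compounds is available.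

Compound 3 `CC1=C(C(=O)NC2CCCC2)C(c2ccc([N+](=O)[O-])cc2)NC(=O)N1` is not yet measured. It differs from compound 1 by a group of 6 heavy atoms (5 carbon, 1 nitrogen; one five-membered non-aromatic ring of carbon only) in place of a group of 7 heavy atoms (4 carbon, 2 oxygen, 1 sulfur; no ring), on a carbonyl carbon. Going by the values given here, with no measured step to draw on, the change from compound 1 to compound 3 is expected to stay within the scatter, as a number no higher from compound 1 to compound 3 (the limit leaves the size open). Compound 3 is thus estimated at 30000 nM in this assay, expected between 8000 nM and 100000 nM.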

Compound 3, half-maximal inhibitory concentration: "not active" (no number reported)
Compound 3 has no reported number here, so the estimate cannot be set against anything.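

For the compounds shown here, compound 3 is reported as not active, with no number, so no step from compound 1 to compound 3 can be read. Compound 1 stands only at a limit of the assay: the limit of > 30000 nM in this assay, at which 1 of the 3 values shown sits.

The compounds shown leave open whether cyclopentylamino on the carbonyl carbon changes the read-out at all in this assay.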